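Chloro for methyl on a quaternary ammonium pyridone amide

The compounds below may be only part of what the source reports. "The series", "measured", "known", "first", "only" and "open" are said of these compounds alone.

Of the compounds shown here, two have been measured in an assay on LX2 cells for inhibition of COL1A1 promoter (Homo sapiens), read by a luciferase reporter, with a stated time of 24 h, tested at 50 uM; on this read-out higher numbers stand for a stronger effect at the one concentration tested and lower numbers for a weaker effect. Compound 1 `CN(C)c1ccc2c(=O)c(C(=O)Nc3cc(F)cc(F)c3)cn(-c3ccc(Cl)c(OCCCCCCC[N+]45CCN(CC4)CC5)c3)c2n1` gives 18.7% in this assay. Compound 2 `CC[N+]1(CCCCCCCOc2cc(-n3cc(C(=O)Nc4cc(F)cc(F)c4)c(=O)c4ccc(N(C)C)nc43)ccc2C)CCCC1` gives 81.4% in this assay, the higher of the two numbers, and the gap between compound 2 and compound 1 lies beyond the usual scatter. Compound 1 and compound 2 differ in more than one place, so no single step can be read from them.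

Compound 3 `CC[N+]1(CCCCCCCOc2cc(-n3cc(C(=O)Nc4cc(F)cc(F)c4)c(=O)c4ccc(N(C)C)nc43)ccc2Cl)CCCC1` has not yet been measured. It differs from compound 2 in one place: chloro in place of methyl on an aromatic carbon. For the measured compounds named here, no measured pair shows the effect of this exact change, so any expectation rests on the two numbers above alone. A small downward step is expected, with a number 16.4 percentage points lower from compound 2 to compound 3 (beyond the scatter) kept modest and within reach of the scatter. Compound 3 is therefore estimated at 65%, within a range from 30% to 90%.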

Compound 3, a percentage reported as inhibition, at one concentration (the size of the read-out at that concentration, not a potency): 96.4%
Compound 3: the middle estimate sits 31.4 percentage points below what was measured; the whole stated range lies below it.
By their numbers in this assay, from the lowest: compound 1; then compound 2; then compound 3.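

In this assay, chloro in place of methyl on this aromatic carbon gives a number 15 percentage points higher from compound 2 to compound 3 (beyond the scatter), so at this position, with the rest of the structure unchanged, chloro is not merely tolerated: the effect rises. With chloro present in both compounds, changing the ring group on the saturated chain, seven bonds along from the oxygen, gives a number 77.7 percentage points higher from compound 1 to compound 3 (beyond the scatter), so in this set that group matters much more than the methyl-to-chloro change. No measurement at hand explains either step.

From the compounds shown here alone, whether bromo or trifluoromethyl on this same aromatic carbon would keep the number high remains open, as does whether chloro would still outperform methyl with the chain-end group of compound 1. Every reading here comes from a single concentration, so these numbers show only a stronger or weaker effect at that concentration.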